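The source may report more compounds than this note shows. Statements on the series, on what has been measured and on what is new or still open speak of the compounds shown alone.

In a functional assay (spleen, spleen) for activation, with Mus musculus as the target (on this read-out higher numbers stand for an effect only at larger amounts of compound and lower numbers for an effect already at smaller amounts), two compounds have been measured so far. Compound 1, `Nc1ncnc2c1nc(O)n2Cc1ccc(Cl)cc1`, gives 10 uM in this assay. Compound 2, `CCCCNc1nc(N)c2nc(O)n(Cc3ccccc3)c2n1`, gives 1 uM in this assay, the lower of the two numbers, and its gap to compound 1 lies beyond the usual scatter of such measurements. Compound 3, `CCCNc1nc(N)c2nc(O)n(Cc3ccccc3)c2n1`, has not yet been measured. It differs from compound 2 in one place: hydrogen in place of methyl on a saturated chain carbon, three bonds along the chain from a nitrogen on an aromatic ring. Going by the values given here, no pair of measured compounds differs in just this way, and the data therefore give no direct guide to the size of this step. A change from butyl to propyl at the far end of such a chain is, in general, a small one, and the step from compound 2 to compound 3 is expected to stay within the scatter, with at most a slight shift toward larger amounts. Compound 3 is accordingly estimated at 1.5 uM, within a range from 0.5 uM to 5 uM. That estimate means an expected step of a 1.5-fold higher number from compound 2 to compound 3 (0.18 log units; within the scatter).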

Compound 3, minimum effective concentration: 0.1 uM
Estimate against measurement, compound 3: 15-fold (1.18 log units) above; the whole stated range lies above it.
By their numbers in this assay, from the lowest: compound 3; then compound 2; then compound 1.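

In this assay, the saturated chain carbon three bonds along the chain from a nitrogen on an aromatic ring proves sensitive: going from butyl to propyl gives a 10-fold lower number from compound 2 to compound 3 (1.00 log units; beyond the scatter). Removing one methyl from the end of this chain is therefore enough to produce an effect at clearly smaller amounts of compound, so a change that looks minor on paper can have a large effect here. No measurement shown explains why this single change has such a large effect.

With only butyl and propyl compared at this place, two chain lengths cannot show whether shortening further to an ethyl chain would continue the shift or reverse it. Going by these compounds, it also remains open how a longer pentyl chain, or a chain ending in a hydroxyl group, would behave.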